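Diphenylamine ethers: cyclopropylamino at the benzylic position

A few compounds are considered here, and "the series" means these few. Any claim that something is new, unique, unknown or untested is made for them only; others in the source may bear on it.

Measured so far, in a functional assay on DLD-1 cells (Homo sapiens) for inhibition, read by MTT assay, with a stated time of 72 h; on this read-out higher numbers stand for weaker inhibition and lower numbers for stronger inhibition:
- compound 1 `CCN1CCN(Cc2c(OC)cc(Oc3cccc(Nc4ccccc4)c3)cc2OC)CC1`: > 20000 nM, a limit of the assay
- compound 2 `COc1cc(Oc2cccc(Nc3ccccc3)c2)cc(OC)c1CNC(C)C`: > 20000 nM, a limit of the assay
- compound 3 `COc1cc(Oc2cccc(Nc3ccccc3)c2)cc(OC)c1CCO`: 18100 nM

Among the measured compounds shown here, compound 3 holds the only read number in this assay; the two other values are limits. Its hydroxymethyl stands against two amines on the saturated chain carbon bound to an aromatic carbon: an at least 1.1-fold lower number from compound 1 to compound 3 (0.04 log units; that floor lies within the scatter) and an at least 1.1-fold lower number from compound 2 to compound 3 (0.04 log units; that floor lies within the scatter), both floors within the scatter, and a step that the two limits leave unreadable from compound 1 to compound 2. Every value sits at or close to the limit of > 20000 nM in this assay, at which 2 of the 3 values shown sit.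

Compound 4 `COc1cc(Oc2cccc(Nc3ccccc3)c2)cc(OC)c1CNC1CC1` is not yet measured. It differs from compound 3 by cyclopropylamino in place of hydroxymethyl on a saturated chain carbon bound to an aromatic carbon. The closest measured analogue is compound 2, whose isopropylamino is also a secondary amine on that carbon, and that compound gave only a limit. For the measured compounds named here, no measured step therefore points to a gain; the expectation is for compound 4 to land at the limit again or just beside it, which means an expected step of a 1.4-fold higher number from compound 3 to compound 4 (0.14 log units; within the scatter) within the scatter. Compound 4 is thus estimated at 25000 nM, within 9000 nM to 80000 nM.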

Compound 4, half-maximal inhibitory concentration: > 20000 nM
Compound 4 was reported as a limit (the forecaster's own chance of this, stated with the estimate: 70%); the middle value lies beyond the limit too.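

In this assay compound 4 gives > 20000 nM, which is a limit. Cyclopropylamino on a saturated chain carbon bound to an aromatic carbon thus joins isopropylamino and 4-ethylpiperazin-1-yl as amines without a read number, so the ring in this amine brings no readable gain; the steps among these three amines cannot be read. The one readable step is an at least 1.1-fold higher number from compound 3 to compound 4 (0.04 log units; that floor lies within the scatter), so the hydroxymethyl of compound 3 is still not separated from the amines, and the series now presses harder against one limit: the limit of > 20000 nM in this assay, at which 3 of the 4 values shown sit.

Going by these compounds, whether a carboxylic acid, an amide or a longer chain ending in a hydroxyl at this place would give a clearly lower number stays open. Also open, on these data alone, is whether a change elsewhere on the shared core would bring these compounds away from the limit.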